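Cytotoxicity limit across aryl groups on the ring nitrogen

The compounds below may be only part of what the source reports. "The series", "measured", "known", "first", "only" and "open" are said of these compounds alone.

Compound 1 `COc1ccc([C@H]2CC(=O)N(C(C)=O)C2)cc1OC1CCCC1` gives > 10000 nM
Compound 2 `COc1ccc([C@H]2CC(=O)N(c3ccccc3)C2)cc1OC1CCCC1` gives > 10000 nM
Compound 3 `COc1ccc([C@H]2CC(=O)N(c3cccc(N)c3C)C2)cc1OC1CCCC1` gives > 10000 nM

In a functional assay on HEK293 cells (Homo sapiens) for cytotoxicity (a lower number here means that less compound is tolerated, a higher number that more compound is tolerated), compound 3 stands at > 10000 nM as a limit and not a number. Among the compounds with values here, the series so far shows the limit of > 10000 nM in this assay, at which 3 of the 3 values shown sit, and no measured number. Compound 4 `COc1ccc([C@H]2CC(=O)N(c3cc(N)cc(F)c3)C2)cc1OC1CCCC1` carries 3-amino-5-fluorophenyl in place of 3-amino-2-methylphenyl on an amide-type nitrogen in a ring, counted as 3-amino-5-fluorophenyl in place of 3-amino-2-methylphenyl on an amide-type nitrogen in a ring in the difference. The closest measured change there is a step that the two limits leave unreadable from compound 2 to compound 3 and gives no size, and neither a step that the two limits leave unreadable from compound 1 to compound 2 nor a step that the two limits leave unreadable from compound 1 to compound 3 gives one. In this assay the expected move is a step that the limit leaves unreadable from compound 3 to compound 4 with no direction and none beyond the scatter. Compound 4 is estimated at 15000 nM with an expected range from 7000 nM to 40000 nM and a limit again the likely report.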

Compound 4, half-maximal cytotoxic concentration: > 10000 nM
Compound 4: a limit, no number; the forecaster's own chance of this, stated with the estimate: 85%; the middle value does not contradict the limit.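

In this assay compound 4 gives > 10000 nM, a limit and not a number, so its steps from compound 1, compound 2 and compound 3 cannot be read. The compounds shown leave open whether any group on the amide-type nitrogen changes the half-maximal cytotoxic concentration, as all values sit at one limit: the limit of > 10000 nM in this assay, at which 4 of the 4 values shown sit.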